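A few compounds are considered here, and "the series" means these few. Any claim that something is new, unique, unknown or untested is made for them only; others in the source may bear on it.

Compound 3 `O=c1ccc(-c2ccccc2)nn1CCCCNC(=S)Nc1cccc2ccccc12` is one of three thioureas built on a shared core. In a functional assay on the whole organism (stomach) with Rattus norvegicus as the target (a lower number here means that less compound is needed, a higher number that more compound is needed for the effect), compound 3 reaches only the limit of > 100 mg/kg, which is not a measured number. Compound 1 `CC(C)(C)/N=C(\S)NCCCCn1nc(-c2ccccc2)ccc1=O` likewise sits at the limit of > 100 mg/kg in this assay. Compound 2 `CC/N=C(\S)NCCCn1nc(-c2ccccc2)ccc1=O` also stops at the limit of > 100 mg/kg in this assay. Compound 3 thus stands at the limit of > 100 mg/kg in this assay, at which 3 of the 3 values shown sit. Compound 4 `C=CCNC(=S)NCCCCn1nc(-c2ccccc2)ccc1=O` carries allyl in place of naphthalen-1-yl on an amide-type nitrogen, that is, allyl in place of naphthalen-1-yl on an amide-type nitrogen. Going by the values given here, no measured step informs this change, so no shift beyond the scatter is expected in this assay. Compound 4 is therefore estimated at 150 mg/kg, between 60 mg/kg and 400 mg/kg, most likely again only a limit. The step this estimate means is expected to be a step that the limit leaves unreadable from compound 3 to compound 4.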

Compound 4, dose for half-maximal effect: > 100 mg/kg
Compound 4 ended at the assay's limit; the forecaster's own chance of this, stated with the estimate: 80%; the middle value is on the limit's open side.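

Compound 4 gives only a limit, so no step from compound 1, compound 2 or compound 3 to compound 4 can be read in this assay: the limit of > 100 mg/kg in this assay, at which 4 of the 4 values shown sit.

The compounds shown leave open whether any thiourea on the shared core gives a measured dose in this assay.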